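The source may report more compounds than this note shows. Statements on the series, on what has been measured and on what is new or still open speak of the compounds shown alone.

Compound 1, `ClCc1cccc(Cn2cnc3c(Cl)nc(Cl)nc32)c1`, was tested in a functional assay on MDA-MB-231 cells (Homo sapiens) for cytotoxicity, read by sulforhodamine B assay, with a stated time of 48 h (on this read-out lower numbers stand for stronger inhibition of growth and higher numbers for weaker inhibition of growth), where compound 1 gives 1950 nM. For the measured compounds named here, the only other measured analogue is compound 2, `Nc1nc(Cl)c2ncn(Cc3ccccc3CCl)c2n1`, and in this assay compound 2 gives 2950 nM. Of the two numbers in hand, compound 1 has the smaller one, but the gap to compound 2 is within the usual scatter of repeated measurements, so the two compounds cannot be told apart on these data, and no ordering between them is claimed.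

The unmeasured compound 3, `ClCc1cccc(Cn2cnc3c(Cl)ncnc32)c1`, is derived from compound 1 by a single change: hydrogen in place of chloro on an aromatic carbon. Going by the values given here, no pair of measured compounds in this set differs in that one place, so there is no measured step to lean on, and the expectation rests on the size of the change alone. Since only a single chlorine is removed and nothing else on the shared core moves, the estimated step of a 1.4-fold higher number from compound 1 to compound 3 (0.14 log units; within the scatter) is small, slightly toward weaker inhibition, and may well not rise above the scatter. In this assay compound 3 is expected to give about 2700 nM, within a range from 1200 nM to 6500 nM.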

Compound 3, concentration for 50% growth inhibition: 1990 nM
Compound 3: middle estimate off by 1.4-fold (0.13 log units), on the high side; the range from low to high includes it.
By their numbers in this assay, from the lowest: compounds 1, 3 and 2 (each within the scatter of the next).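

In this assay, a 1.0-fold higher number from compound 1 to compound 3 (0.01 log units; within the scatter) shows that replacing the chloro group on this aromatic carbon, between two ring nitrogen atoms, with hydrogen leaves the read-out within the scatter. The earlier compounds shown here offered no comparison of this kind, whereas this pair isolates this one place on the shared core. On this pair, the chloro group at this carbon is not required to keep growth inhibition at the level seen for compound 1.

With only chloro and hydrogen shown at this carbon, the result says nothing about how a methoxy group, a methyl group or a carboxylic acid would behave there. It also leaves open whether the chloro group that remains in compound 3, or the chloromethyl group, can be changed as freely, and no measurement in hand accounts for the flat step.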